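The compounds below may be only part of what the source reports. "The series", "measured", "known", "first", "only" and "open" are said of these compounds alone.

Measured so far in a functional assay on ECa-109 cells for inhibition, with ECa-109 cell line (Homo sapiens) as the target, read by sulforhodamine B assay; on this read-out higher numbers stand for weaker inhibition and lower numbers for stronger inhibition:
- compound 1, `Cc1ccc(NC2=CC(=O)c3nc4n(c3C2=O)[C@H]2OC[C@@H](O)[C@H]2OC4)cc1`: 3480 nM
- compound 2, `CCOc1ccc(NC2=CC(=O)c3c(nc4n3[C@H]3OC[C@@H](O)[C@H]3OC4)C2=O)cc1`: > 4000 nM, a limit of the assay and not a number
- compound 3, `O=C1C(Nc2ccccc2)=CC(=O)c2c1nc1n2[C@H]2OC[C@@H](O)[C@H]2OC1`: 3560 nM

Compound 1 holds the lowest of the two numbers in this assay, yet compound 3 sits within the scatter of it, so no order between compound 1 and compound 3 can be read. Compound 2 gives only a limit in this assay, as noted by the limit of > 4000 nM in this assay, at which 1 of the 3 values shown sits.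

Compound 4, `CCCc1ccc(NC2=CC(=O)c3nc4n(c3C2=O)[C@H]2OC[C@@H](O)[C@H]2OC4)cc1`, differs from compound 1 by ethyl in place of hydrogen on a saturated chain carbon bound to an aromatic carbon. One measured step varies the same aromatic carbon: an at least 1.1-fold lower number from compound 2 to compound 3 (0.05 log units; that floor lies within the scatter), a step within the scatter. Compound 1 and compound 3, methyl against hydrogen on an aromatic carbon, likewise give numbers within the scatter of each other. Neither observation points in a direction, so no step beyond the scatter is expected in this assay for the change from methyl to propyl.

Compound 4 is therefore expected near 3500 nM, with a range from 1500 nM to 8000 nM. The expected step is a 1.0-fold higher number from compound 1 to compound 4 (0.00 log units; within the scatter). Because compound 2 reached only the limit recorded as the limit of > 4000 nM in this assay, at which 1 of the 3 values shown sits, a fair chance remains that compound 4 is reported as a limit rather than a number.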

Compound 4, half-maximal inhibitory concentration: > 4000 nM
Compound 4 ended at the assay's limit; the forecaster's own chance of this, stated with the estimate: 35%; middle value at least 1.1-fold (0.05 log units) away from the limit.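

In this assay compound 4 gives > 4000 nM, a limit of the assay and not a number. The step reads an at least 1.1-fold higher number from compound 1 to compound 4 (0.06 log units; that floor lies within the scatter), so the change from methyl to propyl has only a floor, and its true size cannot be read. What is new is that ethoxy in compound 2 and propyl in compound 4, on the same aromatic carbon, both end at the limit, while methyl in compound 1 and hydrogen in compound 3 return numbers within the scatter of each other; among these four compounds, none goes against this split: the limit of > 4000 nM in this assay, at which 2 of the 4 values shown sit.

Going by these compounds, how far compound 2 and compound 4 lie past the limit stays open, and so does whether ethyl, or a chain longer than propyl, would return a number at this place. Also open, on these data alone, is whether an amine, a carboxylic acid or a chlorine atom on that aromatic carbon would give a number lower than that of compound 1 by more than the scatter.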